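The source may hold more compounds than are shown below. What is called first, only, known or untested is meant among the compounds shown, and "the series" means these compounds.

Two compounds of this series have been run so far, compound 1 `COc1cc(-c2nc(C(c3ccc(F)cc3)c3ccc(F)cc3)sc2CC(=O)O)ccn1` and compound 2 `O=C(O)Cc1sc(C(c2ccccc2)c2ccccn2)nc1-c1ccc(Cl)cc1`. In an in vitro functional assay on HEK285-7 cells for antagonist activity at prostaglandin D2 receptor 2 (Homo sapiens), read by BRET and beta-arrestin recruitment (on this read-out lower numbers stand for smaller maximal responses and higher numbers for larger maximal responses), compound 1 gives 60% and stands at the top of the two numbers, although compound 2 gives 55%, a figure within the usual scatter of compound 1, so no order between them is established. Compound 3 `Cc1cc(-c2nc(C(c3ccc(F)cc3)c3ccc(F)cc3)sc2CC(=O)O)ccn1` differs from compound 1 in one place: methyl in place of methoxy on an aromatic carbon. Going by the values given here, no measured step of this kind exists, so there is nothing to anchor a direction. The step of a number 2 percentage points lower from compound 1 to compound 3 (within the scatter) is expected to stay within the scatter. Compound 3 is estimated at 58% in this assay, with a range from 40% to 75%.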

Compound 3, largest response reached (reported as efficacy), in percent of the reference or control that the assay uses: 80%
Estimate against measurement, compound 3: 22 percentage points below; the measured number lies above the stated range.
By their numbers in this assay, from the lowest: compounds 2 and 1 (each within the scatter of the next); then compound 3.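

Methyl in place of methoxy on this aromatic carbon, next to the ring nitrogen, gives in this assay a number 20 percentage points higher from compound 1 to compound 3 (beyond the scatter). Going by these compounds alone, the maximal response therefore depends on the group at this position while the rest of the core stays the same, and this single step is the only one so far. No available evidence bears on the reason for this step. Open, on these data alone, is whether the response follows the oxygen atom or the size of the group; an ethyl, a hydroxyl, an amine or a chlorine here could separate the two.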